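A few compounds are considered here, and "the series" means these few. Any claim that something is new, unique, unknown or untested is made for them only; others in the source may bear on it.

Working notes on the series.

Three compounds share one core and are measured in an assay on isolated protein for inhibition of cathepsin S (Homo sapiens); a lower number here means a stronger inhibitor, a higher number a weaker inhibitor. Compound 1 `COc1ccccc1N1CCN(CCCCn2nc(-c3ccc(Cl)cc3)c3c2CCN(C(C)=O)C3)CC1` gives 9500 nM. Compound 2 `CC(=O)N1CCc2c(c(-c3ccc(Cl)cc3)nn2CC(O)CN2CCN(c3ccccc3Cl)CC2)C1` gives 1000 nM. Compound 3 `COc1ccccc1N1CCN(CC(O)Cn2nc(-c3ccc(I)cc3)c3c2CCN(C(C)=O)C3)CC1` gives 600 nM. Compound 3 thus carries the lowest number of the three; its gap to compound 2 lies within the usual scatter, so no order between those two is claimed, while the gap to compound 1 lies beyond the scatter. Among the measured compounds shown here, compounds 2 and 3 differ in more than one place, so no single step between them is read.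

Compound 4 `CC(=O)N1CCc2c(c(-c3ccc(I)cc3)nn2CC(O)CN2CCN(c3ccccc3C#N)CC2)C1` is not yet measured. It differs from compound 3 by cyano in place of methoxy on an aromatic carbon. For the measured compounds named here, no measured pair in this set isolates that exchange, so there is no precedent to lean on. The expectation for this step is a small move, in either direction or none beyond the scatter, written as a 1.1-fold lower number from compound 3 to compound 4 (0.04 log units; within the scatter). In this assay compound 4 is therefore estimated at 550 nM, with a range from 200 nM to 1600 nM.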

Compound 4, half-maximal inhibitory concentration: 120 nM
Compound 4: the middle estimate sits 4.6-fold (0.66 log units) above what was measured; the measured number lies below the stated range.
By their numbers in this assay, from the lowest: compound 4; then compounds 3 and 2 (each within the scatter of the next); then compound 1.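

In this assay, among the compounds shown here, cyano in place of methoxy on an aromatic carbon, ortho to a large group, gives a 5.0-fold lower number from compound 3 to compound 4 (0.70 log units; beyond the scatter), the first single-place step that can be read. The place on this aromatic ring therefore responds to the exchange, even though the two groups match in heavy atoms, hydrogen-bond acceptors and net charge. Nothing available bears on the reason for this step.

The compounds shown do not tell how a fluorine, a trifluoromethyl or a primary amide would read at this place. Nor do they tell whether the same exchange gives a similar step with the chlorophenyl group of compound 2 or the chain of compound 1.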